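From 4-Fluorobenzyl to Pentyl on the Ring Amine

The source may hold more compounds than are shown below. What is called first, only, known or untested is meant among the compounds shown, and "the series" means these compounds.

Compound 1 `COC1Cc2sccc2C2(CCNCC2)O1` gives 602 nM in an assay on membranes from brain for displacement of a labelled ligand from Sigma non-opioid intracellular receptor 1 (Cavia porcellus); a higher number here means a weaker inhibitor, a lower number a stronger inhibitor. Compound 2 `COC1Cc2sccc2C2(CCN(Cc3ccc(F)cc3)CC2)O1` gives 0.62 nM and stands lowest of the two, the step of a 970-fold lower number from compound 1 to compound 2 (2.99 log units; beyond the scatter) being large. Compound 3 `CCCCCN1CCC2(CC1)OC(OC)Cc1sccc12` differs from compound 2 by butyl in place of 4-fluorophenyl on a saturated chain carbon bound to an amine nitrogen in a ring. For the measured compounds named here, no measured step covers this change; the only measured step shows how much the substituent on the ring amine matters. For compound 3 a moderate rise beyond the scatter is expected, a 4.0-fold higher number from compound 2 to compound 3 (0.61 log units; beyond the scatter), since part of that gain should remain. Compound 3 is estimated at 2.5 nM (range 0.5 nM to 12 nM).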

Compound 3, inhibition constant: 1.6 nM
For compound 3 the middle estimate is 1.6-fold (0.19 log units) above the measured one; the measured number falls inside the stated range.
By their numbers in this assay, from the lowest: compound 2; then compound 3; then compound 1.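

The ring of the 4-fluorobenzyl group is not needed for strong binding at this position: going to pentyl gives only a 2.6-fold higher number from compound 2 to compound 3 (0.41 log units; beyond the scatter), a modest loss that still lies beyond the scatter. A plain saturated chain thus keeps most of the gain, since pentyl in place of hydrogen on the ring amine gives a 380-fold lower number from compound 1 to compound 3 (2.58 log units; beyond the scatter), a large step like that seen with 4-fluorobenzyl. Nothing at hand explains why these two substituents behave so alike. From the compounds shown here alone, how propyl, a longer chain such as octyl, or unsubstituted benzyl would compare on the ring amine stays open.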